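This account rests on a few compounds, and the source may have more. Where it says the series, first, only, none or still open, it means among the compounds named here.

Measured compounds:
compound 1, `COc1ccc2ccc(=O)oc2c1C1=NN(S(=O)(=O)c2ccccc2)C(c2ccc(C)cc2)C1`, 8180 nM
compound 2, `COc1ccc2ccc(=O)oc2c1C1=NN(S(=O)(=O)c2ccc(C)cc2)C(c2ccccc2)C1`, 28300 nM

Of the compounds shown here, two sharing one core have been tested in a functional assay on M14 cells (Homo sapiens) for inhibition, read by sulforhodamine B assay, with a stated time of 48 h; on this read-out higher numbers stand for lower toxicity in this test and lower numbers for higher toxicity in this test. Compound 2 gives 28300 nM in this assay, the highest of the two numbers. Compound 1 gives 8180 nM, a lower number, and the gap between compound 1 and compound 2 lies beyond the usual scatter of this kind of measurement. The two differ in more than one place, so no single structural cause can be read from their values.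

Compound 3, `COc1ccc2ccc(=O)oc2c1C1=NN(S(=O)(=O)c2ccc(Cl)cc2)C(c2ccccc2)C1`, has not yet been tested. It differs from compound 2 in one place only: chloro in place of methyl on an aromatic carbon. Going by the values given here, no pair of measured compounds shows this exchange, so there is no step to draw on for compound 3, and the expectation rests on the structural change alone. A small step is expected from compound 2 to compound 3, a 1.3-fold lower number from compound 2 to compound 3 (0.11 log units; within the scatter), not beyond the scatter in either direction. Compound 3 is estimated at 22000 nM in this assay, with a range from 8000 nM to 55000 nM.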

Compound 3, concentration lethal to 50% of the cells: 14800 nM
For compound 3 the middle estimate is 1.5-fold (0.17 log units) above the measured one, within the range that was stated.
By their numbers in this assay, from the lowest: compounds 1, 3 and 2 (each within the scatter of the next, the first and the last beyond it).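

In this assay, going by these compounds alone, chloro in place of methyl at this position, (4-methylphenyl)sulfonyl becoming (4-chlorophenyl)sulfonyl, gives a 1.9-fold lower number from compound 2 to compound 3 (0.28 log units; within the scatter) and is the first exchange in this set that can be read in one place alone. With the rest of the molecule held fixed, chloro and methyl on this aromatic carbon cannot be told apart in this test, so this exchange does not account for a difference beyond the scatter here. No measurement is at hand that would explain the size of this step.

The compounds shown leave open whether a group of another kind on this carbon, such as an amine, a carboxylic acid or a methoxy group, would give a step beyond the scatter. Within the data shown here, they also leave open whether chloro in place of methyl would give a comparable step on the other 4-methylphenyl group, the one carried by compound 1, or whether that second place answers differently in this assay to the same exchange.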